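Methyl for Fluoro, Repeated on a Second Core

The compounds below may be only part of what the source reports. "The series", "measured", "known", "first", "only" and "open" are said of these compounds alone.

Compound 1 `Cc1ccc(-c2n[nH]cc2N2CCCNCC2)cc1` and compound 2 `Fc1ccc(-c2n[nH]cc2N2CCCNCC2)cc1` share one core, while compound 3 `Fc1ccc(-c2n[nH]cc2N2CCNCC2)cc1` and compound 4 `Cc1ccc(-c2n[nH]cc2N2CCNCC2)cc1` share another; the difference between the two cores is not broken down here. All four are judged in an assay on isolated protein for binding affinity to 5-hydroxytryptamine receptor 3A (Homo sapiens); on this read-out lower numbers stand for stronger inhibition and higher numbers for weaker inhibition.

In this assay compound 2 gives 1810 nM. Compound 1 gives 744 nM. The change from one to the other is methyl in place of fluoro on an aromatic carbon, and it made a 2.4-fold lower number from compound 2 to compound 1 (0.39 log units; beyond the scatter).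

For compound 3 this assay gives only a limit, > 10000 nM. That limit is the limit of > 10000 nM in this assay, at which 1 of the 3 values shown sits.

Compound 4 has not yet been measured. Its difference from compound 3 is methyl in place of fluoro on an aromatic carbon, the same change as from compound 2 to compound 1, in the same place on the ring. If the change works in the same way on the second core, the number for compound 4 is expected to come down to about the extent seen in a 2.4-fold lower number from compound 2 to compound 1 (0.39 log units; beyond the scatter). Because compound 3 reached only the limit > 10000 nM, the starting point for that step is not a number, so the result for compound 4 may again be a limit rather than a value.

Compound 4 is estimated at 6000 nM, expected to fall between 2000 nM and 20000 nM, which would be a step of an at least 1.6-fold lower number from compound 3 to compound 4 (0.22 log units; that floor lies within the scatter).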

Compound 4, inhibition constant: > 10000 nM
Compound 4 ended at the assay's limit; the forecaster's own chance of this, stated with the estimate: 45%; middle value at least 1.6-fold (0.22 log units) away from the limit.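

In this assay compound 4 gives > 10000 nM as a limit of the assay and not a number. No step can be read from compound 3 to compound 4, because both compounds sit at the same limit: the limit of > 10000 nM in this assay, at which 2 of the 4 values shown sit. The compounds shown leave open whether methyl in place of fluoro on an aromatic carbon changes the number on the core of compound 3 the way it does on the core of compound 1.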